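The compounds below may be only part of what the source reports. "The series", "measured", "known", "first", "only" and "open" are said of these compounds alone.

Of the compounds shown here, two with a shared core have been measured in a functional assay for antagonist activity at P2X purinoceptor 7 (Homo sapiens), read by FLIPR and calcium flux; a lower number here means a stronger inhibitor, a higher number a weaker inhibitor. Compound 1, `Clc1cccc(-n2ncnc2Nc2ccccc2)c1Cl`, gives 363 nM in this assay. Compound 2, `Cc1ccccc1CNc1ncnn1-c1cccc(Cl)c1Cl`, gives 20.9 nM in this assay. Compound 2 therefore holds the lowest of the two numbers, and its nearest neighbour, compound 1, stands a good deal higher, with a gap that lies beyond the usual scatter.

Compound 3, `CCOc1ccccc1CNc1ncnn1-c1cccc(Cl)c1Cl`, has not been measured. It differs from compound 2 by ethoxy in place of methyl on an aromatic carbon. Among the compounds with values here, no measured pair in this set shows the effect of such a change, so the direction of the step rests on expectation alone. The ortho position already carries a small group in compound 2, so a modest rise in the number, or none beyond the scatter, is expected for compound 3, with a step of a 1.7-fold higher number from compound 2 to compound 3 (0.22 log units; within the scatter). Compound 3 is thus estimated at 35 nM in this assay, within a range from 10 nM to 120 nM.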

Compound 3, half-maximal inhibitory concentration: 45.7 nM
Compound 3: the middle estimate sits 1.3-fold (0.12 log units) below what was measured; low and high end bracket the measured number.
By their numbers in this assay, from the lowest: compound 2; then compound 3; then compound 1.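

In this assay, within the data shown here, the change from methyl to ethoxy on this aromatic carbon, ortho to a large group, gives a 2.2-fold higher number from compound 2 to compound 3 (0.34 log units; beyond the scatter) and is the first step that can be read at this position. It shows that the number stays sensitive to what sits here, though the step is modest even as three heavy atoms replace one and a hydrogen-bond acceptor enters. Nothing available accounts for this step.

On these data alone, whether an amine, a carboxylic acid or a longer alkoxy chain in this place would lower the number or raise it further remains open. As far as these compounds go, with a single step at this position, it also remains open whether methyl is better here than plain hydrogen.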